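Triazole nitrogen substituent swap in the chromene series

A few compounds are considered here, and "the series" means these few. Any claim that something is new, unique, unknown or untested is made for them only; others in the source may bear on it.

compound 1 `CCOC(=O)C1=Cc2ccccc2OC1(OCc1cn(CC(=O)Nc2cccc(Cl)c2)nn1)C(F)(F)F` — 10100 nM
compound 2 `CCOC(=O)C1=Cc2ccccc2OC1(OCc1cc(-c2ccc([N+](=O)[O-])cc2)no1)C(F)(F)F` — > 150000 nM

Of the compounds shown here, two of the shared core have been measured in a functional assay on DU-145 cells (Homo sapiens) for inhibition, read by MTT assay, with a stated time of 24 h; a higher number here means a weaker inhibitor, a lower number a stronger inhibitor. Among the compounds with values here, compound 1 gives 10100 nM, the only plain number in the set. For compound 2 the value is a limit of the assay, (the limit of > 150000 nM in this assay, at which 1 of the 2 values shown sits), not a number. Within the data shown here, compound 1 is therefore the sole reference point; it sits at the one measured number, with the other result a limit.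

Compound 3 `CCOC(=O)C1=Cc2ccccc2OC1(OCc1cn(-c2cccc(C(F)(F)F)c2)nn1)C(F)(F)F` is not yet measured. It differs from compound 1 by 3-(trifluoromethyl)phenyl in place of ((3-chlorophenyl)carbamoyl)methyl on an aromatic nitrogen. Among the measured compounds shown here, no step between measured compounds covers this kind of change, so no size can be read off. A step of modest size is expected in this assay, more likely toward weaker than stronger, but not clearly beyond the scatter. For compound 3 the expected step is a 1.5-fold higher number from compound 1 to compound 3 (0.17 log units; within the scatter). The estimate for compound 3 is 15000 nM, within 4000 nM to 60000 nM.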

Compound 3, half-maximal inhibitory concentration: > 150000 nM
Compound 3 gave a limit, no number (the forecaster's own chance of this, stated with the estimate: 20%); at least 10-fold (1.00 log units) between middle value and limit.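

In this assay, the aromatic nitrogen on the five-membered ring proves sensitive to its substituent: 3-(trifluoromethyl)phenyl in place of ((3-chlorophenyl)carbamoyl)methyl gives an at least 14-fold higher number from compound 1 to compound 3 (1.17 log units; beyond the scatter), the first step read at this position. The hydrogen-bond donor and acceptor of the outgoing group leave with the change, while a six-membered aromatic ring of carbon only is present on both sides, so such a ring on this nitrogen is not enough to keep the activity of compound 1. On these data alone, compound 3 returns a limit of the assay, not a number, so the true size of the step stays unknown: the limit of > 150000 nM in this assay, at which 2 of the 3 values shown sit.

The change alters the chain and the ring substituent together, and the compounds shown do not separate the two. A 3-chlorophenyl set directly on this nitrogen, or a carboxylic acid or an amine on a short chain there, would test each part alone.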